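The source may hold more compounds than are shown below. What is called first, only, known or untested is meant among the compounds shown, and "the series" means these compounds.

Measured so far:
Compound 1 `Cc1ccccc1-c1cc2ccc(N(C)C)cc2nc1N` gives 6800 nM in a toxicity assay on J774.A1 cells (Mus musculus) for cytotoxicity, read by SYBR Green assay, with a stated time of 1 h; on this read-out lower numbers stand for an effect already at smaller amounts and higher numbers for an effect only at larger amounts of compound
Compound 2 `COc1ccccc1-c1cc2ccc(N(C)C)cc2nc1N` gives 4800 nM in this assay

Among the compounds with values here, compound 1 has only one measured neighbour, and the two numbers lie within the scatter of each other. Compound 3 `CN(C)c1ccc2cc(-c3ccccn3)c(N)nc2c1` has not yet been measured. It carries pyridin-2-yl in place of 2-methylphenyl on an aromatic carbon of the core of compound 1 (pyridin-2-yl in place of 2-methylphenyl on an aromatic carbon). Within the data shown here, only one measured step bears on this, and only indirectly: methoxy in place of methyl on an aromatic carbon gave a 1.4-fold lower number from compound 1 to compound 2 (0.15 log units; within the scatter) and left the ring itself unchanged. Among the measured compounds shown here, no measured compound shows what exchanging that ring does, so the expectation is loose. On the evidence of compound 2, no step beyond the scatter is expected in this assay in either direction. The expected step is a 1.0-fold higher number from compound 1 to compound 3 (0.01 log units; within the scatter) as an estimate only. Compound 3 is estimated at 7000 nM with an expected range from 2500 nM to 20000 nM in this assay overall.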

Compound 3, half-maximal effective concentration: 2200 nM
For compound 3 the middle estimate is 3.2-fold (0.50 log units) above the measured one, outside the stated range (below it).
By their numbers in this assay, from the lowest: compound 3; then compounds 2 and 1 (each within the scatter of the next).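

The ring at this position matters in this assay: pyridin-2-yl in place of 2-methylphenyl gives a 3.1-fold lower number from compound 1 to compound 3 (0.49 log units; beyond the scatter). Exchanging methoxy for methyl on the ring had not shown this, with a 1.4-fold lower number from compound 1 to compound 2 (0.15 log units; within the scatter), which stays within the scatter. The change to the ring is thus the first one here to move the number beyond the scatter, though only modestly, and the measurements available offer no explanation for the step.

The compounds shown leave open whether the step goes with the ring nitrogen that enters or with the methyl group and ring carbon that leave. A plain phenyl or a pyridin-3-yl ring at this position would separate the two, and a pyridin-2-yl ring bearing an amine would show whether the lower number persists.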